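Cyclopropylmethyl core with a 2,5-dimethoxyphenyl sulfonyl

The source may hold more compounds than are shown below. What is called first, only, known or untested is meant among the compounds shown, and "the series" means these compounds.

Compound 2 `Cc1ccc(S(=O)(=O)n2c(N)nc3c2c(=O)n(CC2CC2)c(=O)n3CC2CC2)cc1` gives 9% in an assay on isolated protein with dual specificity calcium/calmodulin-dependent 3',5'-cyclic nucleotide phosphodiesterase 1B (Bos taurus) as the target, tested at 100 uM; on this read-out higher numbers stand for more inhibition at the one concentration tested (going by the name of the read-out) and lower numbers for less inhibition. Going by the values given here, its only measured neighbour, compound 1 `Nc1nc2c(c(=O)n(CC3CC3)c(=O)n2CC2CC2)n1S(=O)(=O)c1ccc(Cl)cc1`, gives 1% in this assay, and the step of a number 8 percentage points higher from compound 1 to compound 2 (within the scatter) is the one change so far on the aryl of the sulfonyl group. Compound 3 `COc1ccc(OC)c(S(=O)(=O)n2c(N)nc3c2c(=O)n(CC2CC2)c(=O)n3CC2CC2)c1` differs from compound 2 by 2,5-dimethoxyphenyl in place of 4-methylphenyl on a sulfonyl sulfur. Among the compounds with values here, only that single step bears on this change, and it stayed within the scatter, so no step beyond the scatter is expected in this assay. For compound 3 the estimate is 6% in this assay, between -6% and 22%, a step of a number 3 percentage points lower from compound 2 to compound 3 (within the scatter).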

Compound 3, a percentage reported as inhibition, at one concentration (the size of the read-out at that concentration, not a potency): 31%
Beside the measured number, compound 3's estimate is 25 percentage points below it; the whole stated range lies below it.
By their numbers in this assay, from the lowest: compounds 1 and 2 (each within the scatter of the next); then compound 3.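

At the sulfonyl sulfur, this assay now shows that the aryl group can move the read-out: 2,5-dimethoxyphenyl in place of 4-methylphenyl gives a number 22 percentage points higher from compound 2 to compound 3 (beyond the scatter) and the same group in place of 4-chlorophenyl gives a number 30 percentage points higher from compound 1 to compound 3 (beyond the scatter) in a modest rise. Going by these compounds alone, the exchange of 4-chlorophenyl for 4-methylphenyl had stayed within the scatter, so this is the first change here to go beyond it. Nothing available explains the rise.

On these data alone, it remains open whether one methoxy group alone would carry this step, or both are needed. An amine or a carboxylic acid on this phenyl ring also remains untested among the compounds shown.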